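Benzyl(methyl)amino Replaces 2-Chlorobenzylamino in a Sulfonamide Series

A few compounds are considered here, and "the series" means these few. Any claim that something is new, unique, unknown or untested is made for them only; others in the source may bear on it.

Of the compounds shown here, three sharing the same sulfonamide core have been measured in a functional assay on A2780 cells (Homo sapiens) for inhibition, read by MTT assay, with a stated time of 72 h; a higher number here means a weaker inhibitor of growth, a lower number a stronger inhibitor of growth. Compound 1 `O=S(=O)(NCCCNCc1ccc(Cl)cc1)c1cc(C(F)(F)F)cc(C(F)(F)F)c1` gives 1800 nM, and compound 2 `COc1cccc(CNCCCNS(=O)(=O)c2cc(C(F)(F)F)cc(C(F)(F)F)c2)c1` gives 1600 nM; the step of a 1.1-fold lower number from compound 1 to compound 2 (0.05 log units; within the scatter) lies within the scatter. Compound 3 `O=S(=O)(NCCCNCc1ccccc1Cl)c1cc(C(F)(F)F)cc(C(F)(F)F)c1` gives 9300 nM, which is the highest number of the three; the step of a 5.2-fold higher number from compound 1 to compound 3 (0.71 log units; beyond the scatter) and the step of a 5.8-fold higher number from compound 2 to compound 3 (0.76 log units; beyond the scatter) both lie beyond the scatter, so compound 3 is the weakest inhibitor of growth among the three.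

The next compound, compound 4 `CN(CCCNS(=O)(=O)c1cc(C(F)(F)F)cc(C(F)(F)F)c1)Cc1ccccc1`, differs from compound 3 by benzyl(methyl)amino in place of (2-chlorobenzyl)amino on a saturated chain carbon, three bonds along the chain from a sulfonamide nitrogen. Within the data shown here, two measured steps bear on this: both show that moving from a 2-chlorophenyl to another substituted phenyl on the saturated chain carbon brings a modest drop in the number. Among the measured compounds shown here, no measured step covers a methyl on the amine nitrogen, so that part of the change is uncharted. On balance a modest fall, a 3.1-fold lower number from compound 3 to compound 4 (0.49 log units; beyond the scatter), is expected, with wide uncertainty. Compound 4 is therefore estimated at 3000 nM, with a range from 1000 nM to 9000 nM.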

Compound 4, concentration for 50% growth inhibition: 28000 nM
Estimate against measurement, compound 4: 9.3-fold (0.97 log units) below, and the stated range ends below it.
By their numbers in this assay, from the lowest: compounds 2 and 1 (each within the scatter of the next); then compound 3; then compound 4.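

At this position, benzyl(methyl)amino gives the weakest inhibitor of growth of the four compounds in this assay, with a 3.0-fold higher number from compound 3 to compound 4 (0.48 log units; beyond the scatter), an 18-fold higher number from compound 2 to compound 4 (1.24 log units; beyond the scatter) and a 16-fold higher number from compound 1 to compound 4 (1.19 log units; beyond the scatter). Among these compounds, the earlier compounds differed only in the substituted phenyl of a benzylamino group, whereas compound 4 is the first to carry a methyl on the amine nitrogen, and its group has 0 hydrogen-bond donors against 1 in (2-chlorobenzyl)amino. Among the compounds shown here, the number thus climbs even past that of compound 3, the weakest of the earlier compounds. Nothing available explains this rise.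

Compound 4 changes the chlorine and the amine nitrogen together, so their separate shares cannot be told apart. A plain benzylamino group, or (4-chlorobenzyl)(methyl)amino, would divide them, and an ethyl on the nitrogen would test the size of that substituent.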